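A few compounds are considered here, and "the series" means these few. Any claim that something is new, unique, unknown or untested is made for them only; others in the source may bear on it.

Series notes. Compound 1 `CCCCOC(=O)CCSC(=S)NCc1cccnc1`, compound 2 `NC(=O)CCSC(=S)NCc1cccnc1` and compound 3 `Fc1ccccc1-c1nnc(CCSC(=S)NCc2cccnc2)o1` share a common core and have all been run in a functional assay on SK-BR-3 cells (Homo sapiens) for cytotoxicity, read by resazurin assay, with a stated time of 72 h; on this read-out higher numbers stand for weaker inhibition and lower numbers for stronger inhibition. Compound 1 gives 4460 nM in this assay, compound 2 gives 1160 nM and compound 3 gives 4690 nM. Compound 3 stands highest of the three numbers on record; compound 1 is nearest to it and within the scatter, while compound 2 is furthest and beyond the scatter. Among the compounds with values here, the single one-point step available, a 3.8-fold lower number from compound 1 to compound 2 (0.58 log units; beyond the scatter), concerns amino in place of butoxy on a carbonyl carbon, a different part of the molecule from the aromatic position at which compound 4 `S=C(NCc1cccnc1)SCCc1nnc(-c2cccnc2)o1` departs from compound 3: pyridin-3-yl in place of 2-fluorophenyl on an aromatic carbon. Within the data shown here, no measured step in this assay tests the exchange of one aromatic ring for another at that place, so nothing in the data argues for a shift in either direction. As far as these compounds go, the expected step of a 1.2-fold lower number from compound 3 to compound 4 (0.07 log units; within the scatter) is therefore none beyond the scatter, with a wide range to reflect that this kind of exchange is untested. Compound 4 is accordingly estimated at 4000 nM in this assay, with a range from 1500 nM to 11000 nM.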

Compound 4, half-maximal inhibitory concentration: 800 nM
The estimate for compound 4 lay 5.0-fold (0.70 log units) above the measured number; the measured number lies below the stated range.
By their numbers in this assay, from the lowest: compounds 4 and 2 (each within the scatter of the next); then compounds 1 and 3 (each within the scatter of the next).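

In this assay, a 5.9-fold lower number from compound 3 to compound 4 (0.77 log units; beyond the scatter) gives the first measured sign that the aromatic group on the five-membered aromatic ring with 2 nitrogen and 1 oxygen bears on the read-out, since this exchange of 2-fluorophenyl for pyridin-3-yl lies beyond the scatter. This place is therefore not indifferent to which six-membered aromatic ring it carries, something the earlier step on a carbonyl carbon, in a different part of the molecule, could not show. The exchange removes the fluorine and brings in a ring nitrogen together, and nothing at hand explains the shift or assigns it to either of these differences.

A plain phenyl group at this place would separate the loss of the fluorine from the entry of the ring nitrogen, while pyridin-2-yl and pyridin-4-yl would test whether the location of that nitrogen matters. Also open, as far as these compounds go, is whether a non-aromatic group here, such as cyclohexyl or a short alkyl chain, keeps the number seen with compound 4.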